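Lengthening the Ester Chain: From Compound 2 to Compound 3

The source may report more compounds than this note shows. Statements on the series, on what has been measured and on what is new or still open speak of the compounds shown alone.

Among the compounds with values here, compound 2 `CCCOC(=O)CCC(=O)N1CCN(CCCOc2cc3c(Nc4ccc(F)c(Cl)c4)ncnc3cc2OC)CC1` gives the lower of the two numbers measured so far in a functional assay on A549 cells (Homo sapiens) for cytotoxicity, read by MTT assay, with a stated time of 24 h, tested at 80 uM; a lower number here means a stronger effect, a higher number a weaker effect of the compound at the concentration tested: compound 2 gives 23.4%, whereas compound 1 `CCOC(=O)CCC(=O)N1CCN(CCCOc2cc3c(Nc4ccc(F)c(Cl)c4)ncnc3cc2OC)CC1` gives 35.6%. Within the data shown here, the single measured step, a number 12.2 percentage points lower from compound 1 to compound 2 (beyond the scatter), came from one added carbon on the ester chain. Compound 3 `CCCCCCCCOC(=O)CCC(=O)N1CCN(CCCOc2cc3c(Nc4ccc(F)c(Cl)c4)ncnc3cc2OC)CC1` has not yet been measured; it differs from compound 2 by pentyl in place of hydrogen on a saturated chain carbon, three bonds along the chain from an oxygen next to a carbonyl group. This is the same kind of change as the measured one, only with a longer chain, so the step from compound 1 to compound 2 is the one that bears on it. That step points to a further move downward, though the data cannot show whether a much longer chain continues the trend. Compound 3 is therefore expected to show a number 8.4 percentage points lower from compound 2 to compound 3 (within the scatter). The estimated value of compound 3 in this assay is 15%, with a range from 4% to 30%.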

Compound 3, a percentage reported as activity, at one concentration (the size of the read-out at that concentration, not a potency): 21.7%
Estimate against measurement, compound 3: 6.7 percentage points below; the measured number falls inside the stated range.
By their numbers in this assay, from the lowest: compounds 3 and 2 (each within the scatter of the next); then compound 1.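

In this assay, the pentyl change gives a number 1.7 percentage points lower from compound 2 to compound 3 (within the scatter), so a much larger addition at this position leaves the read-out no different from that of compound 2, although the earlier one-carbon step had gone beyond the scatter. The long chain still holds the separation from the shortest ester in the series, with a number 13.9 percentage points lower from compound 1 to compound 3 (beyond the scatter), so compound 2 and compound 3 both stand apart from compound 1 by more than the scatter. Nothing available here accounts for this result.

The compounds shown leave open how ester chains of intermediate length, such as butyl or pentyl, would compare with compound 2 and compound 3. They also leave open whether a branched chain, or an amine or a carboxylic acid at the end of the chain, would shift the number.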